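One More Carbon on the Side Chain

The source may report more compounds than this note shows. Statements on the series, on what has been measured and on what is new or still open speak of the compounds shown alone.

Compound 1 `CCCCCCCCCCn1cc(-c2nc3ccccc3cc2C)nn1`: > 100 ug/mL
Compound 2 `CCCCCCCCCCn1cc(-c2nc3ccccc3cc2CC)nn1`: 34.3 ug/mL
Compound 3 `CCc1cc2ccccc2nc1-c1cn(-c2ccc(F)cc2)nn1`: > 100 ug/mL

In a functional assay on THP-1 cells (Homo sapiens) for cytotoxicity, read by MTT assay, with a stated time of 24 h (on this read-out higher numbers stand for weaker inhibition and lower numbers for stronger inhibition), compound 1 gives > 100 ug/mL, which is a limit of the assay and not a number. Compound 2 gives 34.3 ug/mL in this assay. The step of an at least 2.9-fold lower number from compound 1 to compound 2 (0.46 log units; beyond the scatter) goes with the change (methyl in place of hydrogen on a saturated chain carbon bound to an aromatic carbon). Compound 3 gives > 100 ug/mL in this assay, again a limit. How the core of compound 1 and the core of compound 3 differ is not broken down here.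

Compound 4 `CCCc1cc2ccccc2nc1-c1cn(-c2ccc(F)cc2)nn1` has not yet been measured in this assay. It differs from compound 3 by methyl in place of hydrogen on a saturated chain carbon, two bonds along the chain from an aromatic carbon. This is the same kind of change as that from compound 1 to compound 2, but not the same: there the place was on a saturated chain carbon bound to an aromatic carbon, here it is two bonds along the chain from an aromatic carbon. Because the limit of > 100 ug/mL in this assay, at which 2 of the 3 values shown sit, holds for compound 3, the starting point for compound 4 is itself only a limit, so the step can only be guessed. An expectation of an at least 1.4-fold lower number from compound 3 to compound 4 (0.15 log units; that floor lies within the scatter) seems reasonable for compound 4, resting on the earlier step of an at least 2.9-fold lower number from compound 1 to compound 2 (0.46 log units; beyond the scatter) for compound 2. Compound 4 is thus estimated at 70 ug/mL, expected to lie between 30 ug/mL and 150 ug/mL.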

Compound 4, half-maximal inhibitory concentration: > 100 ug/mL
Compound 4 ended at the assay's limit; the forecaster's own chance of this, stated with the estimate: 45%; middle value at least 1.4-fold (0.15 log units) away from the limit.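

No step can be read from compound 3 to compound 4, because both stand at a limit of the assay and not at a number: the limit of > 100 ug/mL in this assay, at which 3 of the 4 values shown sit. The compounds shown leave open whether going from ethyl to propyl on the core of compound 3 changes the number at all in this assay, and whether the step seen on the core of compound 1 carries over.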